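The source may report more compounds than this note shows. Statements on the series, on what has been measured and on what is new or still open speak of the compounds shown alone.

Of the compounds shown here, three have been measured in a functional assay on the whole organism (strain Sprague-Dawley CD) for inhibition, with Rattus norvegicus as the target, read by paw edema, at a dose of 30 mg/kg by the oral route; on this read-out lower numbers stand for a weaker effect and higher numbers for a stronger effect at the one dose given. Compound 1, `CCOC(=O)C(=O)Nc1ccccc(C)c1=O`, gives 6% in this assay. Compound 2, `CCOC(=O)C(=O)Nc1ccccc(N(C)C(=O)C(=O)OCC)c1=O`, gives 6%. Compound 3, `CC(C)(C)OC(=O)C(=O)Nc1cccccc1=O`, gives 47%, the highest of the three numbers; its distance from compound 1 and from compound 2 lies beyond the scatter in each case. Compound 1 and compound 2 are within the scatter of each other, so no order between them can be read. Going by the values given here, no pair among the measured compounds differs in only one place, so no single step on this read-out is documented yet, and the three values do not show which feature carries the higher number of compound 3.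

The next compound, compound 4, `O=C(Nc1cccccc1=O)C(=O)Oc1ccccc1`, has not been measured. It differs from compound 3 at a single place: phenyl in place of tert-butyl on an oxygen next to a carbonyl group. Among the compounds with values here, no measured pair shows what a change on an oxygen next to a carbonyl group does here, so the expectation rests on compound 3 alone.

With compound 3 as the only anchor, a downward step a number 12 percentage points lower from compound 3 to compound 4 (beyond the scatter) is estimated, of a size that may fall within the scatter or a little beyond it. For compound 4 the estimated value in this assay is 35%, with a range from 10% to 60%.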

Compound 4, a percentage reported as inhibition, in the whole organism at one dose (the size of the read-out at that dose, not a potency): 31%
Beside the measured number, compound 4's estimate is 4 percentage points above it; the range from low to high includes it.
By their numbers in this assay, from the lowest: compounds 1 and 2 (each within the scatter of the next); then compound 4; then compound 3.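

In this assay the series now has its first documented single change: phenyl in place of tert-butyl on an oxygen next to a carbonyl group gives a number 16 percentage points lower from compound 3 to compound 4 (beyond the scatter) as a modest step. Going by these compounds alone, the group on this oxygen therefore affects the read-out, yet the exchange does not remove the effect, since compound 4 still gives 31% at the one dose given; tert-butyl is thus not the only group here that goes with a clear number. No measurement at hand gives a reason for the step.

Within the data shown here, compound 1 and compound 2 differ from compound 3 and compound 4 in more than one place, so no steps to them can be read, and what separates their numbers from those of the other two stays open. From the compounds shown here alone, two points also remain open: whether the lower number with phenyl extends to other groups on this oxygen, such as benzyl or a longer chain, and how the carboxylic acid, with hydrogen on this oxygen, would read at the same dose.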